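Replacing the Aryl Group on a Weak MCF7 Inhibitor

The source may hold more compounds than are shown below. What is called first, only, known or untested is meant among the compounds shown, and "the series" means these compounds.

Compound 1 `COc1ccc(-c2nnc(SCCCN3CCN(c4nc5ccccc5o4)CC3)o2)cc1` is the strongest inhibitor of the three measured in a functional assay on MCF7 cells (Homo sapiens) for inhibition, read by MTT assay, with a stated time of 72 h (a higher number here means a weaker inhibitor, a lower number a stronger inhibitor), where compound 1 gives 52800 nM. Compound 2 `Brc1ccc(-c2nnc(SCCCN3CCN(c4nc5ccccc5o4)CC3)o2)cc1` gives 115000 nM and compound 3 `Oc1ccc(-c2nnc(SCCCN3CCN(c4nc5ccccc5o4)CC3)o2)cc1` gives 260000 nM, so the steps of a 2.2-fold higher number from compound 1 to compound 2 (0.34 log units; beyond the scatter) and a 4.9-fold higher number from compound 1 to compound 3 (0.69 log units; beyond the scatter) both run toward weaker inhibition. Compound 4 `O=C(NCc1nnc(SCCCN2CCN(c3nc4ccccc4o3)CC2)o1)c1ccccc1` differs from compound 1 by benzamidomethyl in place of 4-methoxyphenyl on an aromatic carbon. For the measured compounds named here, no measured step involves this change; each measured step, like a 2.3-fold higher number from compound 2 to compound 3 (0.35 log units; beyond the scatter), swaps only one group on the ring that leaves here, and all are modest. The estimate therefore rests on compound 1 with a wide range. Compound 4 is expected to give 80000 nM (range 30000 nM to 250000 nM), a step of a 1.5-fold higher number from compound 1 to compound 4 (0.18 log units; within the scatter) expected to be modest at most.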

Compound 4, half-maximal inhibitory concentration: 52700 nM
The estimate for compound 4 lay 1.5-fold (0.18 log units) above the measured number; measured number inside the range.
By their numbers in this assay, from the lowest: compounds 4 and 1 (each within the scatter of the next); then compound 2; then compound 3.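

For the compounds shown here, earlier steps changed only one group on the aromatic ring, but this one replaces the whole 4-methoxyphenyl group with benzamidomethyl, and the number holds (a 1.0-fold lower number from compound 1 to compound 4 (0.00 log units; within the scatter)). At this position, then, the aromatic ring need not be bonded directly to the core. Benzamidomethyl also compares well with the other aryl groups (a 2.2-fold lower number from compound 2 to compound 4 (0.34 log units; beyond the scatter); a 4.9-fold lower number from compound 3 to compound 4 (0.69 log units; beyond the scatter)), and no measurement here explains these results. Still open, going by these compounds, is whether a simple amine or a carboxylic acid here would give a similar number, and whether the amide link matters compared with a plain carbon chain ending in phenyl.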